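A benzyloxy group in place of chloro

The source may hold more compounds than are shown below. What is called first, only, known or untested is meant among the compounds shown, and "the series" means these compounds.

Values in an ADME assay on L6 cells (Rattus norvegicus) for cytotoxicity, read by fluorescence and resazurin assay, with a stated time of 70 h; a lower number here means a stronger inhibitor, a higher number a weaker inhibitor:
Compound 1 `N=C(N)Nc1ccc2[nH]c(-c3ccc(Cl)cc3)nc2c1`: 71.1 ug/mL
Compound 2 `N#Cc1ccc(-c2nc3cc(NC(=N)N)ccc3[nH]2)cc1`: > 100 ug/mL
Compound 3 `N=C(N)Nc1ccc2[nH]c(-c3ccc(-c4ccccc4)cc3)nc2c1`: 46.2 ug/mL

Compound 2 gives only a limit, > 100 ug/mL. Compound 1 has one neighbour with a true number: the swap of chloro for phenyl gives a 1.5-fold lower number from compound 1 to compound 3 (0.19 log units; within the scatter). Compound 4 `N=C(N)Nc1ccc2[nH]c(-c3ccc(OCc4ccccc4)cc3)nc2c1` carries a different replacement of the chloro, (benzyloxy in place of chloro on an aromatic carbon). The phenyl step is the closest guide, as benzyloxy also brings in a six-membered aromatic ring of carbon only. The cyano step, an at least 1.4-fold higher number from compound 1 to compound 2 (0.14 log units; that floor lies within the scatter), rests on a limit and sets only a floor. In this assay, a small drop within the scatter is therefore expected, in line with a 1.5-fold lower number from compound 1 to compound 3 (0.19 log units; within the scatter). The estimated step is a 1.4-fold lower number from compound 1 to compound 4 (0.15 log units; within the scatter). For compound 4 the expected value is 50 ug/mL, with an estimated range of 20 ug/mL to 100 ug/mL.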

Compound 4, half-maximal inhibitory concentration: 43.2 ug/mL
The estimate for compound 4 lay 1.2-fold (0.06 log units) above the measured number, within the range that was stated.
By their numbers in this assay, from the lowest: compounds 4, 3 and 1 (each within the scatter of the next). At a limit, above all of these: compound 2.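

In this assay, replacing chloro with the much larger benzyloxy group leaves the number within the scatter, a 1.6-fold lower number from compound 1 to compound 4 (0.22 log units; within the scatter). Benzyloxy and phenyl also cannot be told apart at this position, a 1.1-fold lower number from compound 3 to compound 4 (0.03 log units; within the scatter), so this larger group with its hydrogen-bond acceptor adds no separation beyond that seen with phenyl. Compound 2 stands at a limit, so its comparison gives only a floor, an at least 2.3-fold lower number from compound 2 to compound 4 (0.36 log units; beyond the scatter): the limit of > 100 ug/mL in this assay, at which 1 of the 4 values shown sits.

As far as these compounds go, whether an amine or a carboxylic acid on this aromatic carbon would read the same remains open. So does whether a longer chain carrying the same ring would stay within the scatter of compound 4.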